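The source may report more compounds than this note shows. Statements on the series, on what has been measured and on what is new or still open speak of the compounds shown alone.

Working notes on the series. The shared core appears in compound 1 `O=C(Nc1ncc(Cc2ccc(F)cc2)s1)c1ccc(Cl)cc1Cl`, compound 2 `CC(C)(C)OC(=O)Nc1ncc(C(Oc2cccc(C#N)c2)c2ccc(Cl)cc2)s1` and compound 3 `CCCCC(CC)CNc1ncc(C(Oc2ccc3cc(Br)ccc3c2)c2ccc(Cl)cc2)s1`. In an ADME assay on HepG2 2.2.15 cells (Homo sapiens) for cytotoxicity (a lower number here means that less compound is tolerated, a higher number that more compound is tolerated), compound 1 gives > 50000 nM, which is a limit of the assay and not a number. In this assay compound 2 likewise gives > 50000 nM, again a limit. For compound 3 this assay reports "not toxic" (no number reported), so no single number places it, and this reading is not a limit of the assay. The two other readings in the set sit at the limit of > 50000 nM in this assay, at which 2 of the 3 values shown sit. Among the measured compounds shown here, no step between two measured compounds can be computed here. Compound 4 `O=C(Nc1ncc(C(Oc2ccc3cc(Br)ccc3c2)c2ccc(Cl)cc2)s1)c1ccccc1` is the next entry, and it differs from compound 3 as follows: benzoyl in place of 2-ethylhexyl on a nitrogen on an aromatic ring. For the measured compounds named here, with every value so far at or beyond the ceiling, no step beyond the scatter is expected in this assay in either direction. Compound 4 is therefore estimated at 60000 nM in this assay, within 20000 nM to 200000 nM, most likely reported once more only as a limit.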

Compound 4, half-maximal cytotoxic concentration: "not toxic" (no number reported)
The entry for compound 4 holds no number; there is nothing to compare the estimate with.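

Compound 3 and compound 4 both read "not toxic" in this assay with no number, and no step can be read between them. The concentration at which any compound shown turns cytotoxic in this assay stays open: the limit of > 50000 nM in this assay, at which 2 of the 4 values shown sit.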